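This account rests on a few compounds, and the source may have more. Where it says the series, first, only, none or still open, it means among the compounds named here.

Working notes on the series. The shared core carries a saturated ring carbon that is varied. Going by the values given here, compound 3 `CC1=Nc2c(O)nc(N)nc2OC1` gives 242000 nM in an assay on isolated protein for inhibition of Dihydrofolate reductase (Homo sapiens), read by spectrophotometry (on this read-out lower numbers stand for stronger inhibition and higher numbers for weaker inhibition), and sits at the low end of the three numbers so far. Compound 1 `CC1=Nc2c(O)nc(N)nc2OC1C` gives 377000 nM in this assay, and the gap a 1.6-fold lower number from compound 1 to compound 3 (0.19 log units; within the scatter) is within the scatter. Compound 2 `CC1=Nc2c(O)nc(N)nc2OC1c1ccccc1` gives 740000 nM; the gap a 3.1-fold lower number from compound 2 to compound 3 (0.49 log units; beyond the scatter) is beyond the scatter, while a 2.0-fold higher number from compound 1 to compound 2 (0.29 log units; within the scatter) is not.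

Compound 4 `Nc1nc(O)c2c(n1)OCC(Cc1ccccc1)=N2` is next; it differs from compound 3 by phenyl in place of hydrogen on a saturated chain carbon bound to a carbon with a double bond to nitrogen. Among the compounds with values here, the only step that bears on it is the one between compound 2 and compound 3, where a phenyl directly on the ring carbon left a modestly higher number than hydrogen. The phenyl in compound 4 sits on a chain carbon rather than on the ring carbon, so that step is only a rough guide. A step of about the same size, upward, is expected: a 2.0-fold higher number from compound 3 to compound 4 (0.30 log units; within the scatter). Compound 4 is therefore estimated at 480000 nM in this assay, with a range from 200000 nM to 1100000 nM.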

Compound 4, half-maximal inhibitory concentration: 28000 nM
Compound 4: middle estimate off by 17-fold (1.23 log units), on the high side; measured number below the stated range.
By their numbers in this assay, from the lowest: compound 4; then compounds 3, 1 and 2 (each within the scatter of the next, the first and the last beyond it).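

In this assay, going by these compounds alone, phenyl on the saturated chain carbon bound to a carbon with a double bond to nitrogen gives an 8.6-fold lower number from compound 3 to compound 4 (0.94 log units; beyond the scatter), the largest step so far and the only one beyond the scatter in which adding a group lowers the number. Phenyl on the saturated ring carbon went the other way, with a 3.1-fold lower number from compound 2 to compound 3 (0.49 log units; beyond the scatter) when it gives way to hydrogen, so in these compounds the outcome of adding phenyl depends on where it is placed. No measurement at hand accounts for this difference.

As far as these compounds go, it remains open whether the lower number requires the aromatic ring itself or only more carbon at this place, which a cyclohexyl group or a longer chain there would help to separate. Also open, from the compounds shown here alone, is how an amine or a carboxylic acid on the phenyl ring would change the number.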